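Phenylsulfonyl on the aromatic nitrogen of compound 1

The compounds below may be only part of what the source reports. "The series", "measured", "known", "first", "only" and "open" are said of these compounds alone.

For the measured compounds named here, in a functional assay on HepG2 cells (Homo sapiens) for antiproliferative activity, read by MTT assay, with a stated time of 24 h (a higher number here means a weaker inhibitor, a lower number a stronger inhibitor), compound 1 (`Cc1ccc(-c2nn(-c3ccccc3)cc2-c2nc3ccccc3[nH]2)cc1`) gives 6260 nM and compound 2 (`FC(F)(F)c1ccc(-c2nn(-c3ccccc3)cc2-c2nc3ccccc3[nH]2)cc1`) gives 6030 nM within the scatter of it, so compound 1 stands level with the only other measured compound. Going by the values given here, compound 3 (`Cc1ccc(-c2nn(-c3ccccc3)cc2-c2nc3ccccc3n2S(=O)(=O)c2ccccc2)cc1`) carries phenylsulfonyl in place of hydrogen on an aromatic nitrogen as its only change. Among the compounds with values here, the one measured step, a 1.0-fold lower number from compound 1 to compound 2 (0.02 log units; within the scatter) as trifluoromethyl replaces methyl on an aromatic carbon, lies elsewhere and gives no size for this change. A modest move to a lower number in this assay is expected, on thin evidence, with an estimated 1.8-fold lower number from compound 1 to compound 3 (0.25 log units; within the scatter) as the working figure. Compound 3 is expected at 3500 nM with 800 nM to 15000 nM as the estimated range.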

Compound 3, half-maximal inhibitory concentration: 960 nM
For compound 3 the middle estimate is 3.6-fold (0.56 log units) above the measured one; the measured number falls inside the stated range.
By their numbers in this assay, from the lowest: compound 3; then compounds 2 and 1 (each within the scatter of the next).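

In this assay, phenylsulfonyl in place of hydrogen on the aromatic nitrogen gives a 6.5-fold lower number from compound 1 to compound 3 (0.81 log units; beyond the scatter), the only step shown that lies beyond the scatter. The hydrogen on this nitrogen is therefore not required for activity in compound 3, and the position accepts a group of 9 heavy atoms. No measured evidence bears on the reason for this step. Open, as far as these compounds go, is whether the phenyl ring or the sulfonyl link carries the step, which methylsulfonyl or benzoyl on the same nitrogen would help separate. Also open, from the compounds shown here alone, is whether phenylsulfonyl gives a similar step on compound 2.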